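The source may report more compounds than this note shows. Statements on the series, on what has been measured and on what is new or still open speak of the compounds shown alone.

Values so far in an ADME assay on BHK cells (Mesocricetus auratus) for cytotoxicity, read by MTT assay, with a stated time of 96 h (on this read-out lower numbers stand for higher toxicity in this test and higher numbers for lower toxicity in this test), are:

- compound 1 (`FC(F)(F)c1cccc(NC(=S)Nc2ccc(Cl)cc2)c1`): 10000 nM
- compound 2 (`FC(F)(F)c1cccc(NC(=S)NCc2ccco2)c1`): 48000 nM
- compound 3 (`FC(F)(F)c1cccc(NC(=S)Nc2ccccc2Br)c1`): not yet measured

Compound 2 holds the higher of the two numbers, which means the lower toxicity in this test. The move to compound 3 is 2-bromophenyl in place of (furan-2-yl)methyl on an amide-type nitrogen and puts 2-bromophenyl in place of (furan-2-yl)methyl on an amide-type nitrogen.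

Within the data shown here, only one measured step bears on this change. It is a 4.8-fold higher number from compound 1 to compound 2 (0.68 log units; beyond the scatter) and came from putting (furan-2-yl)methyl in place of 4-chlorophenyl at that same kind of nitrogen. That step is modest but beyond the scatter. Compound 3 goes the opposite way, from (furan-2-yl)methyl back to a substituted phenyl group, so a step of similar size towards a lower number is expected in this assay for now. Among the measured compounds shown here, no measured compound carries 2-bromophenyl, and the reasoning rests on a single pair, so the range must stay wide. The estimated step is a 4.0-fold lower number from compound 2 to compound 3 (0.60 log units; beyond the scatter) in this test. Compound 3 is estimated at 12000 nM with an expected range from 4000 nM to 35000 nM in this test.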

Compound 3, half-maximal cytotoxic concentration: 59000 nM
Beside the measured number, compound 3's estimate is 4.9-fold (0.69 log units) below it; measured number above the stated range.
By their numbers in this assay, from the lowest: compound 1; then compounds 2 and 3 (each within the scatter of the next).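

In this assay, putting 2-bromophenyl in place of (furan-2-yl)methyl on the amide-type nitrogen gives a 1.2-fold higher number from compound 2 to compound 3 (0.09 log units; within the scatter), so at this nitrogen a halogen-bearing phenyl group and the furan-containing group cannot be told apart in this test. Swapping one halogen-bearing phenyl group for another gives a 5.9-fold higher number from compound 1 to compound 3 (0.77 log units; beyond the scatter), which means that the earlier contrast cannot be read as a general one between phenyl groups and (furan-2-yl)methyl: among these three compounds, only the one carrying 4-chlorophenyl stands apart, and 2-bromophenyl goes against any such phenyl rule. No measured evidence here accounts for this difference between the two phenyl groups.

The groups 4-chlorophenyl and 2-bromophenyl differ both in their halogen and in where it sits on the ring, so these compounds leave open which of the two matters, a question that 4-bromophenyl, 2-chlorophenyl or a plain phenyl group at the same nitrogen could help to settle. Also open, from the compounds shown here alone, is how this read-out would respond to quite different groups there, such as a longer carbon chain or a chain ending in an amine or a carboxylic acid.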